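The source may hold more compounds than are shown below. What is called first, only, known or untested is meant among the compounds shown, and "the series" means these compounds.

Measured so far in a functional assay on the whole organism for inhibition, with Brassica rapa subsp. chinensis as the target, with a stated time of 3 days, tested at 100 ppm; on this read-out higher numbers stand for more inhibition of growth at the one concentration tested and lower numbers for less inhibition of growth:
- compound 1 `CCCOC(=O)/C=C/c1ccc(C(C)C)cc1` gives 5%
- compound 2 `CCC(C)OC(=O)/C=C/c1ccccc1` gives 20%
- compound 3 `CCC(C)NC(=O)/C=C/c1ccccc1` gives 77%

Compound 3 holds the highest number of the three. Its nearest neighbour is compound 2, and the step of a number 57 percentage points higher from compound 2 to compound 3 (beyond the scatter) lies beyond the scatter; compound 1 sits further off still, with both esters, compound 1 and compound 2, clustered at the low end of the range.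

Compound 4 `CCCOC(=O)/C=C/c1ccccc1` has not been measured. It differs from compound 3 in one place: propoxy in place of (sec-butyl)amino on a carbonyl carbon. Among the measured compounds shown here, the only measured step that speaks to this is a number 57 percentage points higher from compound 2 to compound 3 (beyond the scatter), which runs in the opposite direction: replacing an ester oxygen by an amide nitrogen on the carbonyl carbon raised growth inhibition by a large margin. Compound 4 undoes that kind of change, so a large fall in this assay is expected from compound 3 to compound 4, bringing compound 4 back toward the ester values of compound 2 and compound 1. The propoxy chain here is one heavy atom shorter than the departing group, and the two measured esters differ among themselves only within a modest spread, so no further precision is available.

For compound 4 the expected value in this assay is 15% (range 0% to 35%), i.e. an expected step of a number 62 percentage points lower from compound 3 to compound 4 (beyond the scatter).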

Compound 4, percent growth inhibition at one concentration: 7%
Compound 4: middle estimate off by 8 percentage points, on the high side, and the stated range covers the measured number.
By their numbers in this assay, from the lowest: compounds 1 and 4 (each within the scatter of the next); then compound 2; then compound 3.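

In this assay, propoxy in place of (sec-butyl)amino on a carbonyl carbon gives a number 70 percentage points lower from compound 3 to compound 4 (beyond the scatter), so the low level seen for the sec-butyl ester also holds for a propyl ester, and the large gap between amide and ester is not tied to one alkoxy group. Among the esters, the alkoxy chain still matters to a modest degree: hydrogen in place of methyl on the saturated chain carbon bound to the oxygen gives a number 13 percentage points lower from compound 2 to compound 4 (beyond the scatter). Hydrogen in place of isopropyl on an aromatic carbon gives a number 2 percentage points higher from compound 1 to compound 4 (within the scatter), so no difference can be read for that change on the propyl ester, although the low level of both compounds leaves little room to see a fall.

Nothing at hand explains any of these steps. Still open, as far as these compounds go, are whether a propylamino group would match the (sec-butyl)amino of compound 3, how a longer chain on the ester oxygen would read, and whether isopropyl on the aromatic carbon stays without a readable difference when carried by the amide, where the level is high.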